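Replacing the methoxymethylpropyl amide substituent with a carboxypentyl chain

The source may report more compounds than this note shows. Statements on the series, on what has been measured and on what is new or still open speak of the compounds shown alone.

The three measured compounds share one core and differ only in the group on the amide nitrogen. Compound 1 `CCCCCCCCCCCC(=O)OC[C@H](CSC[C@@H](N)C(=O)NC(C)(C)CO)OC(=O)CCCCCCCCCCC` gives 15500 nM in an assay on HEK293 cells for agonist activity at Toll-like receptor 2 (Homo sapiens); a lower number here means that less compound is needed, a higher number that more compound is needed for the effect. Compound 2 `CCCCCCCCCCCC(=O)OC[C@H](CSC[C@@H](N)C(=O)NCCCS(=O)(=O)O)OC(=O)CCCCCCCCCCC` gives 5560 nM. Compound 3 `CCCCCCCCCCCC(=O)OC[C@H](CSC[C@@H](N)C(=O)NC(CC)COC)OC(=O)CCCCCCCCCCC` gives 71.8 nM, the lowest of the three numbers, with a 220-fold lower number from compound 1 to compound 3 (2.33 log units; beyond the scatter) and a 77-fold lower number from compound 2 to compound 3 (1.89 log units; beyond the scatter). Compound 4 `CCCCCCCCCCCC(=O)OC[C@H](CSC[C@@H](N)C(=O)NCCCCCC(=O)O)OC(=O)CCCCCCCCCCC` is not yet measured; it differs from compound 3 in one place: 5-carboxypentyl in place of 1-(methoxymethyl)propyl on an amide-type nitrogen.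

For the measured compounds named here, no measured step involves a 5-carboxypentyl group, so the expectation rests on the neighbouring steps. Both known changes away from the 1-(methoxymethyl)propyl group reach much higher numbers, and the step of a 2.8-fold lower number from compound 1 to compound 2 (0.45 log units; beyond the scatter) shows that the two open-chain alternatives sit far from compound 3. The author therefore expects a large step upward for compound 4, estimated as a 35-fold higher number from compound 3 to compound 4 (1.54 log units; beyond the scatter), because the reverse direction of a 77-fold lower number from compound 2 to compound 3 (1.89 log units; beyond the scatter) was large. Compound 4 is estimated at 2500 nM, with a range from 300 nM to 20000 nM.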

Compound 4, half-maximal effective concentration: 108 nM
The estimate for compound 4 lay 23-fold (1.36 log units) above the measured number; measured number outside the range, below it.
By their numbers in this assay, from the lowest: compounds 3 and 4 (each within the scatter of the next); then compound 2; then compound 1.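

In this assay, the 5-carboxypentyl group on the amide-type nitrogen stands level with the 1-(methoxymethyl)propyl group, with a 1.5-fold higher number from compound 3 to compound 4 (0.18 log units; within the scatter) as the step, so a low number at this position is not confined to the ether-bearing substituent. The same compound also stands far from the other two, with a 51-fold lower number from compound 2 to compound 4 (1.71 log units; beyond the scatter) and a 140-fold lower number from compound 1 to compound 4 (2.16 log units; beyond the scatter) as its steps, which shows that an open chain ending in an acid group can give a low number here even though the 3-sulfopropyl chain does not. Nothing available here explains these steps.

The compounds shown leave open how the number responds to a shorter or longer carboxyalkyl chain. They also leave open whether the carboxylic acid itself matters, which a methyl ester, a primary amide or an amine at the chain end would test.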